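The source may report more compounds than this note shows. Statements on the series, on what has been measured and on what is new or still open speak of the compounds shown alone.

Compound 1 `Cc1cc(C)cc(C(=O)c2cc(Cl)ccc2Oc2ccnc(Nc3ccc(C#N)cc3)n2)c1` gives 28800 nM in an ADME assay on MT4 cells (Homo sapiens) for cytotoxicity, read by MTT assay, with a stated time of 5 days; on this read-out higher numbers stand for lower toxicity in this test and lower numbers for higher toxicity in this test. Compound 2 `Cc1ccccc1C(=O)c1cc(Cl)ccc1Oc1ccnc(Nc2ccc(C#N)cc2)n1` gives 28800 nM. Compound 3 `N#Cc1ccc(Nc2nccc(Oc3ccc(C(=O)c4ccc(O)cc4)cc3)n2)cc1` gives 19400 nM.

Compound 1 stands level with compound 2, the two together the highest of the three numbers; the step of no change at the digits printed from compound 1 to compound 2 (within the scatter) lies within the scatter, and compound 3 is likewise within the scatter of compound 1. Compound 4 `Cc1cc(C)cc(C(=O)c2cc(Cl)ccc2Oc2cc(C)nc(Nc3ccc(C#N)cc3)n2)c1` differs from compound 1 by methyl in place of hydrogen on an aromatic carbon. Going by the values given here, the single measured step concerns the aryl on the carbonyl, not this position of the shared core, so no measured step bears directly on the change. With nothing to suggest otherwise, a step of a 1.1-fold lower number from compound 1 to compound 4 (0.03 log units; within the scatter) within the scatter is expected. For compound 4 an estimated 27000 nM, between 12000 nM and 60000 nM, is expected in this assay.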

Compound 4, half-maximal cytotoxic concentration: 37100 nM
Beside the measured number, compound 4's estimate is 1.4-fold (0.14 log units) below it, within the range that was stated.
By their numbers in this assay, from the lowest: compounds 3, 1, 2 and 4 (each within the scatter of the next).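

Going by these compounds alone, the step of a 1.3-fold higher number from compound 1 to compound 4 (0.11 log units; within the scatter) in this assay is the only measured change on the shared core rather than on the aryl on the carbonyl, and it lies within the scatter. In this one pair, methyl in place of hydrogen on this aromatic carbon, next to the ring nitrogen, has no effect beyond the scatter on the read-out. No measured evidence here explains this result.

Going by these compounds, whether an ethyl group, a methoxy group or an amine on this carbon would also stay within the scatter remains open. On these data alone, it is also open whether methyl here would give the same result with the 2-methylphenyl on the carbonyl of compound 2.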